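The source may report more compounds than this note shows. Statements on the series, on what has been measured and on what is new or still open speak of the compounds shown alone.

Three compounds make up the account so far: compound 1 `Nc1ncnc2c1c(-c1cnc3[nH]ccc3c1)nn2CC(=O)NO`, compound 2 `Nc1nc2cc(-c3nn(CCC(=O)NO)c4ncnc(N)c34)ccc2o1` and compound 3 `Nc1ncnc2c1c(-c1cnc3[nH]ccc3c1)nn2CCC(=O)NO`. In a functional assay on HeLa cells (Homo sapiens) for inhibition, read by MTT assay, with a stated time of 72 h (a lower number here means a stronger inhibitor, a higher number a weaker inhibitor), compound 1 has "not determined" (no result reported). Compound 3 likewise has "not determined" (no result reported). Compound 2 reads > 150000 nM, which is a limit of the assay and not a number. The evidence so far therefore amounts to the limit of > 150000 nM in this assay, at which 1 of the 3 values shown sits.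

Compound 4 `CNC(=O)CCCCCCCn1nc(-c2ccc3oc(N)nc3c2)c2c(N)ncnc21` differs from compound 2 as follows: 5-(methylcarbamoyl)pentyl in place of hydroxycarbamoyl on a saturated chain carbon, two bonds along the chain from an aromatic nitrogen. In words, 5-(methylcarbamoyl)pentyl stands in place of hydroxycarbamoyl on a saturated chain carbon, two bonds along the chain from an aromatic nitrogen.

Within the data shown here, no measured pair shows what such an exchange does, so the expectation is tentative. A measurable result for compound 4 could only lie on the stronger side of the limit of compound 2, > 150000 nM. A moderate gain in this assay is expected, with the estimated step being an at least 5.0-fold lower number from compound 2 to compound 4 (0.69 log units; beyond the scatter). For compound 4, the estimated value is 30000 nM, with an expected range of 3000 nM to 150000 nM.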

Compound 4, half-maximal inhibitory concentration: 12900 nM
Estimate against measurement, compound 4: 2.3-fold (0.37 log units) above; low and high end bracket the measured number.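

Among these compounds, compound 4 gives the first value in this account that is a number and not a limit, so a change at this position can now be followed in this assay. Compound 2 stands at > 150000 nM, which is a limit of the assay and not a number. Putting 5-(methylcarbamoyl)pentyl in place of hydroxycarbamoyl on a saturated chain carbon, two bonds along the chain from an aromatic nitrogen, gives an at least 11-fold lower number from compound 2 to compound 4 (1.06 log units; beyond the scatter), which shows that a measurable value in this series does not require the hydroxycarbamoyl group.

The step changes the chain length and the end group together, and the compounds shown leave open what each contributes. A longer chain ending in hydroxycarbamoyl, or one ending in a carboxylic acid or an amine, would be needed to separate the two.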